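A few compounds are considered here, and "the series" means these few. Any claim that something is new, unique, unknown or untested is made for them only; others in the source may bear on it.

Measured compounds in a functional assay on C6 cells (Rattus norvegicus) for cytotoxicity, read by MTT assay, with a stated time of 24 h, tested at 6 ug/mL; on this read-out lower numbers stand for a stronger effect and higher numbers for a weaker effect at the one concentration tested:
compound 1, `Cn1cnnc1SCC(=O)N/N=c1/scc(-c2ccc(C#N)cc2)n1-c1ccccc1`, gives 70.2%
compound 2, `Cn1nnnc1SCC(=O)N/N=c1/scc(-c2ccc(C#N)cc2)n1-c1ccccc1`, gives 63.5%
compound 3, `O=C(CSc1nnnn1-c1ccccc1)N/N=c1/scc(-c2ccc(Br)cc2)n1-c1ccccc1`, gives 61.8%

Compound 1 carries the highest number of the three, but its gaps to compound 2 and to compound 3 both lie within the scatter of repeated measurements, so no ordering among the three compounds can be read from these numbers. Among the measured compounds shown here, the single step measured between compounds that differ in one place, a number 6.7 percentage points lower from compound 1 to compound 2 (within the scatter), concerns the heterocycle on the sulfur and stays within the scatter.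

Compound 4, `Cn1cnnc1SCC(=O)N/N=c1/scc(-c2ccccc2)n1-c1ccccc1`, is not yet measured. It differs from compound 1 by hydrogen in place of cyano on an aromatic carbon. For the measured compounds named here, no measured step touches this position: the only single-place step in hand changes another part of the molecule, and compound 3, which differs from compound 1 in more than one place, also gives a number within the scatter of compound 1. Nothing in the data therefore points to a step beyond the scatter in this assay in either direction, and the expectation for compound 4 rests on compound 1 alone.

The value of compound 4 in this assay is estimated at 72%, with a range from 57% to 87%. This estimate corresponds to an expected step of a number 1.8 percentage points higher from compound 1 to compound 4 (within the scatter), which is expected to remain within the scatter.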

Compound 4, a percentage reported as activity, at one concentration (the size of the read-out at that concentration, not a potency): 90%
Compound 4: the middle estimate sits 18 percentage points below what was measured; the measured number lies above the stated range.
By their numbers in this assay, from the lowest: compounds 3, 2 and 1 (each within the scatter of the next); then compound 4.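

In this assay, hydrogen in place of cyano on the aromatic carbon gives a step of a number 19.8 percentage points higher from compound 1 to compound 4 (beyond the scatter), and since higher numbers stand for a weaker effect, the 4-cyanophenyl group goes with more of the effect than the phenyl group at the one concentration tested. This is the first single-place step in the series to lie beyond the scatter, whereas the change of heterocycle on the sulfur, a number 6.7 percentage points lower from compound 1 to compound 2 (within the scatter), stays within it, so this position is the one place shown where a single change registers on this read-out. No measurement at hand accounts for the step.

Still open, as far as these compounds go, is whether the step belongs to cyano itself or would appear with other groups on that aromatic carbon, such as an amino group, a carboxylic acid or a methoxy group. Also open, from the compounds shown here alone, is whether the same change from 4-cyanophenyl to phenyl gives a step of similar size with the 1-methyl-1H-tetrazol-5-yl group of compound 2 on the sulfur, and how far any of this holds at other concentrations.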